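A Carbonyl Swap on a Weak Compound

The source may report more compounds than this note shows. Statements on the series, on what has been measured and on what is new or still open speak of the compounds shown alone.

Compound 1 `COc1cc(C2OC(c3ccc(N)c(C)c3)=NN2C(C)=O)cc(OC)c1OC` gives 0.059 uM
Compound 2 `COC(=O)N1N=C(c2ccc(N(C)C)cc2)OC1c1cc(OC)c(OC)c(OC)c1` gives 106 uM

In a functional assay on NCI-H460 cells (Homo sapiens) (a higher number here means that more compound is needed for the effect, a lower number that less compound is needed), compound 2 has the higher of the two numbers, well beyond the scatter from compound 1, so far more of it is needed for the effect. Compound 3 `COc1cc(C2OC(c3ccc(N(C)C)cc3)=NN2C(=O)CN)cc(OC)c1OC` carries aminomethyl in place of methoxy on a carbonyl carbon in its difference from compound 2. For the measured compounds named here, no measured pair shows this change alone. A move to lower numbers, beyond the scatter, is therefore only expected, resting on the low value of compound 1 (0.059 uM). The expected size is a 53-fold lower number from compound 2 to compound 3 (1.72 log units; beyond the scatter) in this estimate. Compound 3 is estimated at 2 uM (range 0.1 uM to 40 uM).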

Compound 3, concentration for half-maximal effect: 0.66 uM
Compound 3: middle estimate off by 3.0-fold (0.48 log units), on the high side; measured number inside the range.
By their numbers in this assay, from the lowest: compound 1; then compound 3; then compound 2.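

In this assay, aminomethyl in place of methoxy on a carbonyl carbon gives a 160-fold lower number from compound 2 to compound 3 (2.21 log units; beyond the scatter), so this one group, on the carbonyl carbon bonded to the amide-type nitrogen in a ring, can by itself shift the number greatly. Compound 1 could not show this, since it differs from compound 2 in more than one place. Nothing measured here explains the step.

Still open, on these data alone, is whether the amine matters or only the loss of methoxy. Hydroxymethyl or the longer aminoethyl on this carbonyl carbon would help separate the two.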